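Hydrazone series: dimethylamino for hydroxy on the aryl ring

The source may report more compounds than this note shows. Statements on the series, on what has been measured and on what is new or still open speak of the compounds shown alone.

Two members of the series have been run in a functional assay on the whole organism (strain Wistar) for inhibition, with Rattus norvegicus as the target, read by paw edema, with a stated time of 2 h, at a dose of 10 mg/kg by the intraperitoneal route; a higher number here means more inhibition at the dose given (going by the name of the read-out), a lower number less inhibition. Compound 1 `O=C(N/N=C/c1cccc(F)c1)c1cccnc1Nc1cccc(C(F)(F)F)c1` gives 52.8% in this assay. Within the data shown here, compound 2 `O=C(N/N=C/c1ccc(O)cc1)c1cccnc1Nc1cccc(C(F)(F)F)c1` gives 68% in this assay, the higher of the two numbers; the step of a number 15.2 percentage points higher from compound 1 to compound 2 (beyond the scatter) is the only measured step so far and lies beyond the scatter.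

The next compound, compound 3 `CN(C)c1ccc(/C=N/NC(=O)c2cccnc2Nc2cccc(C(F)(F)F)c2)cc1`, keeps the shared core of compound 2 and changes only the substituent on the aryl ring of the hydrazone: dimethylamino in place of hydroxy on an aromatic carbon. Among the measured compounds shown here, no measured pair tells what a dimethylamino does in this place. For the measured compounds named here, the one step in hand, a number 15.2 percentage points higher from compound 1 to compound 2 (beyond the scatter), concerns a different exchange on the same ring and shows only that the number in this assay is higher after that exchange. It gives no direction for the present change, so no step beyond the scatter is expected in this assay, and compound 2 remains the reference point.

For compound 3 the expected value in this assay is 60%, with a range of 44% to 76%, an expected step of a number 8 percentage points lower from compound 2 to compound 3 (within the scatter).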

Compound 3, a percentage reported as inhibition, in the whole organism at one dose (the size of the read-out at that dose, not a potency): 51.4%
Beside the measured number, compound 3's estimate is 8.6 percentage points above it; the measured number falls inside the stated range.
By their numbers in this assay, from the lowest: compounds 3 and 1 (each within the scatter of the next); then compound 2.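

In this assay this aromatic carbon, para to a large group, is now shown to be sensitive to the group it carries: dimethylamino in place of hydroxy gives (a number 16.6 percentage points lower from compound 2 to compound 3 (beyond the scatter)), so the higher number of compound 2 does not come with any group at this place. Set against the 3-fluorophenyl of compound 1, the 4-(dimethylamino)phenyl gives (a number 1.4 percentage points lower from compound 1 to compound 3 (within the scatter)), so these two aryl groups cannot be told apart here, and only compound 2 stands clear of the others, with steps beyond the scatter to both. The exchange removes the hydrogen-bond donor of hydroxy and brings in carbon and nitrogen, but this single pair cannot separate those differences, and nothing measured on hand accounts for the step.

Still open is whether the higher number stays with hydroxy alone, since the compounds shown include no methoxy, primary amine or carboxylic acid on this carbon to test it. Also open, going by these compounds, is whether the same exchange would give a step of similar size with a different group in place of the 3-(trifluoromethyl)phenyl part of the shared core.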